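The source may hold more compounds than are shown below. What is called first, only, known or untested is meant among the compounds shown, and "the series" means these compounds.

Compound 1 `O=c1c(-c2ccc(F)cc2)cn(C2CC2)c2cc(N3CCNCC3)c(F)cc12` in a functional assay on HeLa cells (Homo sapiens) for antiproliferative activity, read by MTT assay, with a stated time of 48 h (a higher number here means a weaker inhibitor, a lower number a stronger inhibitor), gives 14900 nM. Compound 2 `O=c1c(-c2ccc(Cl)cc2)cn(C2CC2)c2cc(N3CCNCC3)c(F)cc12` gives 9300 nM in this assay. Compound 3 `O=c1c(-c2cccc(F)c2)cn(C2CC2)c2cc(N3CCNCC3)c(F)cc12` gives 9160 nM in this assay, and the values of compound 2 and compound 3 lie within the scatter of each other. Compound 4 `O=c1c(-c2cccc(Cl)c2)cn(C2CC2)c2cc(N3CCNCC3)c(F)cc12` is still to be measured in this assay.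

From compound 1 to compound 2 the change is chloro in place of fluoro on an aromatic carbon and it made a 1.6-fold lower number from compound 1 to compound 2 (0.20 log units; within the scatter). The cores of compound 1 and compound 3 differ by 3-fluorophenyl in place of 4-fluorophenyl on an aromatic carbon. The change from compound 3 to compound 4 is chloro in place of fluoro on an aromatic carbon, the same kind of change as from compound 1 to compound 2, though not the same: in compound 1 the exchanged halogen sits para to a large group, in compound 3 it sits meta to a large group.

For compound 4 a step of a 1.4-fold lower number from compound 3 to compound 4 (0.15 log units; within the scatter) is expected, set beside a 1.6-fold lower number from compound 1 to compound 2 (0.20 log units; within the scatter) in the earlier pair; the expectation rests on that earlier step a 1.6-fold lower number from compound 1 to compound 2 (0.20 log units; within the scatter), with the differing surroundings of the place kept in mind. Compound 4 is estimated at 6500 nM, expected between 3000 nM and 14000 nM.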

Compound 4, half-maximal inhibitory concentration: 890 nM
Compound 4: middle estimate off by 7.3-fold (0.86 log units), on the high side; the measured number lies below the stated range.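

Chloro in place of fluoro on an aromatic carbon does not carry over as one fixed step between these two cores in this assay: the same change on two cores in this assay, a 1.6-fold lower number (0.20 log units; within the scatter) from compound 1 to compound 2 and a 10-fold lower number (1.01 log units; beyond the scatter) from compound 3 to compound 4, 6.4-fold (0.81 log units) apart, beyond the scatter of two such steps

The large step on the core of compound 3 is a 10-fold lower number from compound 3 to compound 4 (1.01 log units; beyond the scatter), and the 3-chlorophenyl group of compound 4 also stands clearly apart from the other two groups, with a 10-fold lower number from compound 2 to compound 4 (1.02 log units; beyond the scatter) against 4-chlorophenyl and a 17-fold lower number from compound 1 to compound 4 (1.22 log units; beyond the scatter) against 4-fluorophenyl. This rests on a single pair for each core, so it shows that the step depends on the surroundings in this series, but it does not show why, nor does it give a rule for any core beyond these two.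

The compounds shown leave open whether bromo, methyl or trifluoromethyl in the same place, meta to a large group, would follow chloro or fluoro. They also leave open how an unsubstituted phenyl group would compare with 3-chlorophenyl.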